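Swapping a methyl for two fluorines on the benzyl cap

The compounds below may be only part of what the source reports. "The series", "measured", "known", "first", "only" and "open" are said of these compounds alone.

Going by the values given here, compound 2 `Cc1cccc(CNC(=O)C(=O)N[C@@H](C)C(=O)N[C@@H](CC(=O)O)C(=O)COc2c(F)c(F)cc(F)c2F)c1` gives 127 nM in a functional assay on Jurkat cells (Homo sapiens) (on this read-out lower numbers stand for stronger inhibition and higher numbers for weaker inhibition), the higher of the two numbers measured so far; compound 1 `C[C@H](NC(=O)C(=O)NCCC1CCCC1)C(=O)N[C@@H](CC(=O)O)C(=O)COc1c(F)c(F)cc(F)c1F` gives 11 nM. Among the compounds with values here, the only measured step, a 12-fold higher number from compound 1 to compound 2 (1.06 log units; beyond the scatter), concerns a different change and so bears only loosely on what follows. Compound 3 `C[C@H](NC(=O)C(=O)NCc1cc(F)cc(F)c1)C(=O)N[C@@H](CC(=O)O)C(=O)COc1c(F)c(F)cc(F)c1F` differs from compound 2 by 3,5-difluorophenyl in place of 3-methylphenyl on a saturated chain carbon bound to an amide-type nitrogen. Within the data shown here, no measured step exchanges one substituent on that ring for another, so the expected step of a 1.3-fold lower number from compound 2 to compound 3 (0.10 log units; within the scatter) is small and may well fall within the scatter. Compound 3 is estimated at 100 nM, with a likely range from 30 nM to 300 nM.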

Compound 3, half-maximal inhibitory concentration: 16 nM
Compound 3: middle estimate off by 6.3-fold (0.80 log units), on the high side; measured number outside the range, below it.
By their numbers in this assay, from the lowest: compounds 1 and 3 (each within the scatter of the next); then compound 2.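

In this assay, the substituents on the benzyl ring clearly matter at this position: 3,5-difluorobenzyl in place of 3-methylbenzyl gives a 7.9-fold lower number from compound 2 to compound 3 (0.90 log units; beyond the scatter) in a single change. The weak number of compound 2 therefore does not hold for every benzyl group, as the change from cyclopentylmethyl to 3,5-difluorophenyl gives only a 1.5-fold higher number from compound 1 to compound 3 (0.16 log units; within the scatter) and stays within the scatter. No measurement offers an explanation for the difference between the two rings. Whether both fluorines are needed remains open, since 3-fluorobenzyl is not among these compounds. As far as these compounds go, how 3-chlorobenzyl or 3,5-dimethylbenzyl would compare also remains unknown.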